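A few compounds are considered here, and "the series" means these few. Any claim that something is new, unique, unknown or untested is made for them only; others in the source may bear on it.

Compound 1 `N#Cc1cnc(NCc2cnccc2C(F)(F)F)cc1N[C@H]1CC[C@@H](O)CC1` gives 100 nM in an assay on isolated protein for inhibition of protein kinase C theta type (Homo sapiens), read by TR-FRET, with a stated time of 2 h; a lower number here means a stronger inhibitor, a higher number a weaker inhibitor. Compound 2 `N#Cc1cnc(NCc2cnccc2C(F)(F)F)cc1N[C@H]1CC[C@@H](C(N)=O)CC1` gives 7 nM, and compound 3 `CC1(C)C[C@H](Nc2cc(NCc3cnccc3C(F)(F)F)ncc2C#N)CC[C@@H]1O` gives 7 nM, so that together these two give the lowest numbers of the three; the step of a 14-fold lower number from compound 1 to compound 3 (1.15 log units; beyond the scatter) was large, while no change at the digits printed from compound 2 to compound 3 (within the scatter). Compound 4 `CC1(C)C[C@@H](Nc2cc(NCc3cnccc3C(F)(F)F)ncc2C#N)CC[C@H]1O` differs from compound 3 in that (the two compounds have the same atoms and bonds and differ only in configuration as drawn: 2 of 2 stereo elements differ (all stereocentres are inverted: mirror images); a stereocentre at a saturated ring carbon is drawn R in compound 3 and S in compound 4; a stereocentre at a saturated ring carbon is drawn S in compound 3 and R in compound 4). Among the measured compounds shown here, none of the measured steps changes configuration; each of them swaps or adds a group, so none bears on this change. Mirror images can give either the same number or a very different one, and the data give no guide. Compound 4 is therefore estimated at 50 nM, within 7 nM to 700 nM, an expected step of a 7.1-fold higher number from compound 3 to compound 4 (0.85 log units; beyond the scatter).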

Compound 4, half-maximal inhibitory concentration: 120 nM
The estimate for compound 4 lay 2.4-fold (0.38 log units) below the measured number; low and high end bracket the measured number.
By their numbers in this assay, from the lowest: compounds 2 and 3 (each within the scatter of the next); then compounds 1 and 4 (each within the scatter of the next).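

Configuration alone decides the result for the 4-hydroxy-3,3-dimethylcyclohexyl group in this assay, with a 17-fold higher number from compound 3 to compound 4 (1.23 log units; beyond the scatter), because nothing else separates this pair: the fact that compounds 3 and 4 differ only in the configuration as drawn. The inverted form shows no gain over the 4-hydroxycyclohexyl group, with a 1.2-fold higher number from compound 1 to compound 4 (0.08 log units; within the scatter), and it also falls short of the 4-carbamoylcyclohexyl group, with a 17-fold higher number from compound 2 to compound 4 (1.23 log units; beyond the scatter).

From the compounds shown here alone, both stereocentres are inverted together in this pair, and which of them carries the difference stays open. Also open, going by these compounds, is whether an amine or a carboxylic acid in place of the hydroxy group would keep the low number.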